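Swapping ethyl for thiophen-3-yl on the shared core

The source may hold more compounds than are shown below. What is called first, only, known or untested is meant among the compounds shown, and "the series" means these compounds.

In a functional assay on Jurkat cells (Homo sapiens) for inhibition (a lower number here means a stronger inhibitor, a higher number a weaker inhibitor), compound 1 (`CCOC(=O)c1cnc(N(C(C)=O)N2C(=O)C=C(C)C2=O)nc1C(F)(F)F`) reads 410 nM and compound 2 (`CCOC(=O)c1cnc(NN2C(=O)C=C(C)C2=O)nc1CC`) reads 400 nM in the same test. Compound 2 therefore stands level with compound 1, within the usual scatter of repeated measurements.

Compound 3 (`CCOC(=O)c1cnc(NN2C(=O)C=C(C)C2=O)nc1-c1ccsc1`) has not yet been measured. It arises from compound 2 by one change, thiophen-3-yl in place of ethyl on an aromatic carbon. That carbon lies next to the ring nitrogen and ortho to an ethoxycarbonyl group.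

Compound 1 carries trifluoromethyl in that place and differs elsewhere too, yet compound 1 at 410 nM still matches the ethyl compound. The two values give no sign that this place responds strongly to its group, though neither compound carries a ring there. In this assay no step beyond the scatter is therefore expected, and the expected change is a 1.1-fold higher number from compound 2 to compound 3 (0.05 log units; within the scatter) in this estimate. The range stays wide, as no direct comparison exists. For compound 3 the estimated value is 450 nM with an expected range from 140 nM to 1500 nM in this test.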

Compound 3, half-maximal inhibitory concentration: 200 nM
The estimate for compound 3 lay 2.3-fold (0.35 log units) above the measured number, and the stated range covers the measured number.
By their numbers in this assay, from the lowest: compounds 3, 2 and 1 (each within the scatter of the next, the first and the last beyond it).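

In this assay the swap gives a 2.0-fold lower number from compound 2 to compound 3 (0.30 log units; within the scatter), so compound 3 and compound 2 cannot be told apart in this test. For the compounds shown here, this shows what the earlier compounds could not: this place, on an aromatic carbon next to the ring nitrogen and ortho to an ethoxycarbonyl group, accepts a five-membered aromatic ring of five heavy atoms in place of a two-carbon chain with no loss beyond the scatter, whereas neither compound 1 nor compound 2 carries a ring there. Nothing further is available that bears on this reading, and a single pair sets no trend with the size or kind of group.

Going by these compounds, it remains open whether this tolerance extends to other groups at this carbon, such as phenyl, an amine or a carboxylic acid, or whether a longer chain such as butyl would read like ethyl. Also open, on these data alone, is whether thiophen-2-yl, with its sulfur placed differently, would read like thiophen-3-yl in this assay.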